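Sulfonamide nitrogen substituents on a coumarin enaminone scaffold

The compounds below may be only part of what the source reports. "The series", "measured", "known", "first", "only" and "open" are said of these compounds alone.

Measured compounds:
Compound 1 `NS(=O)(=O)c1ccc(N/C=C\C(=O)c2cc3ccccc3oc2=O)cc1` gives 109000 nM in a functional assay on T47D cells (Homo sapiens) for cytotoxicity, read by sulforhodamine B assay, with a stated time of 48 h; a higher number here means a weaker inhibitor, a lower number a stronger inhibitor.
Compound 2 `Cc1noc(NS(=O)(=O)c2ccc(N/C=C\C(=O)c3cc4ccccc4oc3=O)cc2)c1C` gives 68400 nM in this assay.
Compound 3 `O=C(/C=C\Nc1ccc(S(=O)(=O)Nc2ccccn2)cc1)c1cc2ccccc2oc1=O` gives 37600 nM in this assay.

Compound 3 gives the lowest number of the three. Its distance from compound 2 is within the scatter, so the two cannot be ordered, while the step of a 2.9-fold lower number from compound 1 to compound 3 (0.46 log units; beyond the scatter) is modest but beyond the scatter. The step of a 1.6-fold lower number from compound 1 to compound 2 (0.20 log units; within the scatter) and the step of a 1.8-fold lower number from compound 2 to compound 3 (0.26 log units; within the scatter) are both within the scatter.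

Compound 4 `COc1cnc(NS(=O)(=O)c2ccc(N/C=C\C(=O)c3cc4ccccc4oc3=O)cc2)nc1` differs from compound 3 by 5-methoxypyrimidin-2-yl in place of pyridin-2-yl on a sulfonamide nitrogen. Going by the values given here, the only measured steps that bear on this are the exchanges at the sulfonamide nitrogen just described: one modest change on going from hydrogen to an aromatic ring, and no change beyond the scatter on going from one ring to another. As compound 4 keeps an aromatic ring on that nitrogen, the expected step of a 1.0-fold higher number from compound 3 to compound 4 (0.00 log units; within the scatter) in this assay is none beyond the scatter. For compound 4 the estimate is therefore 38000 nM, within a range from 15000 nM to 95000 nM.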

Compound 4, half-maximal inhibitory concentration: 8800 nM
Estimate against measurement, compound 4: 4.3-fold (0.64 log units) above; measured number below the stated range.
By their numbers in this assay, from the lowest: compound 4; then compounds 3, 2 and 1 (each within the scatter of the next, the first and the last beyond it).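

At this sulfonamide nitrogen, the exchange of one aromatic ring for another can matter: a 4.3-fold lower number from compound 3 to compound 4 (0.63 log units; beyond the scatter), whereas the earlier exchange of one ring for another stayed within the scatter. The 5-methoxypyrimidin-2-yl group also stands apart from the other ring and from hydrogen, with a 7.8-fold lower number from compound 2 to compound 4 (0.89 log units; beyond the scatter) and a 12-fold lower number from compound 1 to compound 4 (1.09 log units; beyond the scatter), so the presence of a ring on this nitrogen does not alone set the number in this assay. No measurement available here accounts for the effect of this group.

The change adds a second ring nitrogen and a methoxy group together, and the compounds shown do not separate the two. A pyrimidin-2-yl group or a 5-methoxypyridin-2-yl group on the same nitrogen would tell them apart.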